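The source may report more compounds than this note shows. Statements on the series, on what has been measured and on what is new or still open speak of the compounds shown alone.

For the measured compounds named here, compound 1, `N=C(S)CCn1nc(-c2ccccc2)ccc1=O`, and compound 2, `Cc1ccc(=O)n(CC(C)C(=N)S)n1`, are the two compounds so far tested in a functional assay on the whole organism (stomach) with Rattus norvegicus as the target; on this read-out higher numbers stand for an effect only at larger amounts of compound and lower numbers for an effect already at smaller amounts. Compound 1 gives 87.3 mg/kg in this assay. For compound 2 this assay reports only a limit, > 100 mg/kg, and not a number. This is the limit of > 100 mg/kg in this assay, at which 1 of the 2 values shown sits. Compound 2 therefore stands at the edge of what this assay can report, and the data place it no more precisely than that.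

Compound 3, `Cc1ccc(=O)n(CCC(=N)S)n1`, differs from compound 2 by hydrogen in place of methyl on a saturated chain carbon bound to a carbon with a double bond to nitrogen and a saturated chain carbon. No measured pair in this set isolates this change, so its direction and size are not shown by the numbers. Going by the values given here, with only one flanking value, and that one a limit, the change in this assay is expected to amount to a number no higher from compound 2 to compound 3 (the limit leaves the size open), that is, nothing beyond the usual scatter of this assay. Compound 3 is expected to give 100 mg/kg in this assay, with a range from 40 mg/kg to 250 mg/kg. Given where compound 2 stands, there is a real chance that compound 3 too is reported only as a limit rather than as a number.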

Compound 3, dose for half-maximal effect: 43.2 mg/kg
Beside the measured number, compound 3's estimate is 2.3-fold (0.36 log units) above it; measured number inside the range.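

Hydrogen in place of methyl on a saturated chain carbon bound to a carbon with a double bond to nitrogen and a saturated chain carbon gives an at least 2.3-fold lower number from compound 2 to compound 3 (0.36 log units; beyond the scatter) in this assay, so this place on the chain now has a direction, with the unbranched compound 3 acting at smaller amounts. That step has a floor and no upper end, as compound 2 is reported only as a limit: the limit of > 100 mg/kg in this assay, at which 1 of the 3 values shown sits. The second step adds a change elsewhere on the shared core, where methyl in place of phenyl on an aromatic carbon gives a 2.0-fold lower number from compound 1 to compound 3 (0.31 log units; beyond the scatter), so the phenyl of compound 1 is not needed for a measured number in this assay, and the smaller methyl goes with the lower one.

The compounds shown leave open how far the chain itself can be changed, for instance whether an ethyl group or a hydroxyl group on this chain carbon, or a longer chain, would read like the methyl or like the hydrogen. They also leave open whether the effect of the chain methyl holds when phenyl rather than methyl sits on the aromatic carbon.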